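A few compounds are considered here, and "the series" means these few. Any claim that something is new, unique, unknown or untested is made for them only; others in the source may bear on it.

Compound 2 `O=S(=O)(NCCNc1nccc(-c2c(-c3cccc(F)c3)nc3sccn23)n1)c1ccc(C(F)(F)F)cc1` was tested in a functional assay on SK-MEL-28 cells (Homo sapiens) for cytotoxicity, read by MTT assay (a lower number here means a stronger inhibitor, a higher number a weaker inhibitor), and gives 8450 nM. Within the data shown here, the only other measured compound, compound 1 `O=S(=O)(NCCCNc1nccc(-c2c(-c3cccc(F)c3)nc3sccn23)n1)c1ccccc1`, gives 6850 nM in this assay, a number within the scatter of that of compound 2, so the two cannot be told apart. Compound 3 `O=S(=O)(NCCNc1nccc(-c2c(-c3cccc(F)c3)nc3sccn23)n1)c1ccccc1` has not been measured. It differs from compound 2 in one place: hydrogen in place of trifluoromethyl on an aromatic carbon. Among the measured compounds shown here, no measured pair shows this change, so nothing in the data fixes its size or direction. The change is expected to leave the number much where it was, a step of a 1.1-fold lower number from compound 2 to compound 3 (0.05 log units; within the scatter), within the scatter. Compound 3 is estimated at 7500 nM, with a range from 3000 nM to 18000 nM.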

Compound 3, half-maximal inhibitory concentration: 19000 nM
Beside the measured number, compound 3's estimate is 2.5-fold (0.40 log units) below it; measured number above the stated range.
By their numbers in this assay, from the lowest: compounds 1 and 2 (each within the scatter of the next); then compound 3.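

In this assay the trifluoromethyl group does matter: replacing 4-(trifluoromethyl)phenyl with phenyl gives a 2.2-fold higher number from compound 2 to compound 3 (0.35 log units; beyond the scatter) and so a weaker compound. The chain matters too, since with phenyl on both sides, (phenylsulfonyl)amino in place of ((phenylsulfonyl)amino)methyl gives a 2.8-fold higher number from compound 1 to compound 3 (0.44 log units; beyond the scatter) and again a weaker compound. Nothing available explains either step. Still open, on these data alone, is whether other groups on this aromatic carbon, such as a chlorine atom or a methoxy group, would hold the activity, and how a longer chain would behave.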